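The compounds below may be only part of what the source reports. "The series", "measured", "known", "first", "only" and "open" are said of these compounds alone.

Measured so far:
compound 1 `OCCc1cn(Cc2ccc(Cl)cc2)c2ccccc12` — in a functional assay on T29Kt1 cells (Homo sapiens) for cytotoxicity, read by sulforhodamine B assay, with a stated time of 3 days (a higher number here means a weaker inhibitor, a lower number a stronger inhibitor), compound 1 gives only a limit, > 31600 nM.
compound 2 `CC(O)c1cn(Cc2ccc(Cl)cc2)c2ccccc12` — in this assay compound 2 gives 19900 nM.

For the measured compounds named here, compound 2 holds the only number in this assay; the other value is a limit (the limit of > 31600 nM in this assay, at which 1 of the 2 values shown sits). Compound 3 `Cc1cn(Cc2ccc(Cl)cc2)c2ccccc12` differs from compound 2 by methyl in place of 1-hydroxyethyl on an aromatic carbon. Going by the values given here, the single measured step, an at least 1.5-fold lower number from compound 1 to compound 2 (0.20 log units; that floor lies within the scatter), alters the group on the same aromatic carbon but keeps its hydroxyl and lies within the scatter, so it gives no direction for the present change. For compound 3 in this assay the expected step is a 1.3-fold higher number from compound 2 to compound 3 (0.10 log units; within the scatter), none beyond the scatter, with a fair chance that only a limit is returned. Compound 3 is estimated at 25000 nM, range 8000 nM to 80000 nM.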

Compound 3, half-maximal inhibitory concentration: > 31600 nM
Compound 3: only a limit was reported (the forecaster's own chance of this, stated with the estimate: 40%); middle value at least 1.2-fold (0.10 log units) away from the limit.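

In this assay, methyl in place of 1-hydroxyethyl on this aromatic carbon gives an at least 1.5-fold higher number from compound 2 to compound 3 (0.20 log units; that floor lies within the scatter), so the hydroxyl-free group is now tested, but its floor does not separate the two compounds. Compound 3 gives only a limit, as does compound 1, and the step between those two limits cannot be read. The series at this position now reads mostly as limits: the limit of > 31600 nM in this assay, at which 2 of the 3 values shown sit.

Open, as far as these compounds go, is how far compound 3 lies past its limit. Also open, from the compounds shown here alone, is whether an amine or a carboxylic acid on this carbon would give a number clearly apart from compound 2.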